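The source may report more compounds than this note shows. Statements on the series, on what has been measured and on what is new or still open speak of the compounds shown alone.

In a functional assay on HCT-116 cells (Homo sapiens) for inhibition, read by MTT assay, with a stated time of 72 h (on this read-out higher numbers stand for weaker inhibition of growth and lower numbers for stronger inhibition of growth), compound 1 (`CC1=C(CCCCCCCCCCn2cc(C[C@H](O)COCCOC[C@@H](O)Cc3ccc(-c4ccccc4)cc3)nn2)C(=O)c2ccccc2C1=O`) gives 3000 nM and compound 2 (`O[C@H](COCCOC[C@@H](O)Cc1cn(Cc2ccc(Oc3ccccc3)cc2)nn1)Cc1ccc(-c2ccccc2)cc1`) gives 3400 nM as its concentration for half-maximal growth inhibition. For the measured compounds named here, these two values lie within the usual scatter of each other, so compound 2 cannot be separated from the only other measured compound. Compound 3 (`O[C@H](COCCOC[C@@H](O)Cc1cn(Cc2ccc(C(F)(F)F)cc2)nn1)Cc1ccc(-c2ccccc2)cc1`) has not yet been measured. It departs from compound 2 by a single change (trifluoromethyl in place of phenoxy on an aromatic carbon), trifluoromethyl in place of phenoxy on an aromatic carbon, para to a large group. Going by the values given here, no measured pair shows this change or one like it, so nothing gives a direct guide to its size in this assay and the expectation stays loose. Taking compound 2 at 3400 nM as the starting point, no step beyond the scatter is expected, with only a slight lean toward weaker inhibition of growth. The estimated change is a 1.2-fold higher number from compound 2 to compound 3 (0.07 log units; within the scatter) on this reasoning. Compound 3 is expected to read 4000 nM within an estimated range of 1500 nM to 12000 nM once it is tested.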

Compound 3, concentration for 50% growth inhibition: 2500 nM
Compound 3: the middle estimate sits 1.6-fold (0.20 log units) above what was measured, within the range that was stated.
By their numbers in this assay, from the lowest: compounds 3, 1 and 2 (each within the scatter of the next).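

For the compounds shown here, with trifluoromethyl in place of phenoxy on an aromatic carbon, para to a large group, this assay gives a 1.4-fold lower number from compound 2 to compound 3 (0.13 log units; within the scatter) and so offers the first reading of any change at this place. Phenoxy, with 7 heavy atoms and one six-membered aromatic ring of carbon only, gives way to trifluoromethyl, with 4 heavy atoms and no ring, yet compound 2 and compound 3 cannot be told apart, so in this pair neither the ring nor the hydrogen-bond acceptor that leaves with phenoxy is needed to keep the reading within the scatter. No measurement at hand offers an explanation for this result.

A single step within the scatter cannot show whether this place is insensitive in general or whether these two groups merely happen to read alike. An amine, a carboxylic acid or a longer chain on the same aromatic carbon would test that question, and each would show whether a group of another kind moves the number beyond the scatter in this assay.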